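The compounds below may be only part of what the source reports. "The series", "measured", "known", "first", "only" and "open" are said of these compounds alone.

The measured compounds:
Compound 1, `COc1cccc(/C=C2\CCC/C(=C\c3ccccc3Br)C2=O)c1OC`. In an ADME assay on NHDF cells (Homo sapiens) for cytotoxicity, read by MTT assay, with a stated time of 72 h (on this read-out higher numbers stand for weaker inhibition and lower numbers for stronger inhibition), compound 1 gives only a limit, > 50000 nM.
Compound 2, `COc1cccc(/C=C2\CCC/C(=C\c3cccc(Br)c3)C2=O)c1OC`. In this assay compound 2 gives 23900 nM.
Compound 3, `COc1cc(/C=C2\CCC/C(=C\c3cccc(OC)c3OC)C2=O)ccc1O`. In this assay compound 3 gives 14300 nM.

Compound 2 holds the highest of the two numbers in this assay; its nearest neighbour is compound 3, and the two lie within the scatter (a 1.7-fold lower number from compound 2 to compound 3 (0.22 log units; within the scatter)), so no order between them can be asserted. The value of compound 1 is a limit, (the limit of > 50000 nM in this assay, at which 1 of the 3 values shown sits), and not a number.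

Compound 4, `COc1cccc(/C=C2\CCC/C(=C\c3ccc(O)c(O)c3)C2=O)c1OC`, is not yet measured. It differs from compound 2 in one place:
3,4-dihydroxyphenyl in place of 3-bromophenyl on a double-bonded chain carbon bound to a double-bonded ring carbon

The step that bears most directly on this change is the one in which the 3-bromophenyl of compound 2 gave way to an oxygen-bearing phenyl at the same place, a 1.7-fold lower number from compound 2 to compound 3 (0.22 log units; within the scatter), which stayed within the scatter. The steps that start from compound 1, an at least 2.0-fold lower number from compound 1 to compound 2 (0.32 log units; beyond the scatter) and an at least 3.4-fold lower number from compound 1 to compound 3 (0.54 log units; beyond the scatter), begin at a limit and only mark a lower bound on the movement. Taken together, these point to a step in this assay from compound 2 to compound 4 that is at most modest and more likely within the scatter, leaning if anything toward a lower number, so that compound 4 is expected to show a 1.5-fold lower number from compound 2 to compound 4 (0.17 log units; within the scatter). On that basis compound 4 is estimated at 16000 nM, with a range from 6000 nM to 45000 nM.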

Compound 4, half-maximal inhibitory concentration: 17900 nM
Compound 4: the middle estimate sits 1.1-fold (0.05 log units) below what was measured, within the range that was stated.
By their numbers in this assay, from the lowest: compounds 3, 4 and 2 (each within the scatter of the next). At a limit, above all of these: compound 1.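

Swapping 3-bromophenyl for 3,4-dihydroxyphenyl on a double-bonded chain carbon bound to a double-bonded ring carbon leaves the read-out in this assay within the scatter, a 1.3-fold lower number from compound 2 to compound 4 (0.13 log units; within the scatter), so losing the bromine and gaining the hydrogen-bond donors that enter with this group brings no change that can be asserted. Hydrogen in place of methyl on an oxygen on an aromatic ring also stays within the scatter, a 1.3-fold higher number from compound 3 to compound 4 (0.10 log units; within the scatter), which means that compound 2, compound 3 and compound 4 cannot be told apart here, whether the ring carries a bromine, a methoxy group or only hydroxyl groups. The remaining step, an at least 2.7-fold lower number from compound 1 to compound 4 (0.44 log units; beyond the scatter), gives only a bound, and the value it starts from is a limit and not a number: the limit of > 50000 nM in this assay, at which 1 of the 4 values shown sits.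

The compounds shown leave open whether an amine or a carboxylic acid on this phenyl ring would move the number beyond the scatter. They also leave open how far compound 1 really lies from the other three compounds.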